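Shifting One Fluorine on the Difluorophenyl Group

The compounds below may be only part of what the source reports. "The series", "measured", "known", "first", "only" and "open" are said of these compounds alone.

Compound 2 `Nc1scc(CN2CCN(c3ccc(F)c(F)c3)CC2)c1C(=O)c1ccc(Cl)cc1` gives 1% in an assay on CHO cells for displacement of a labelled ligand from adenosine receptor A3 (Homo sapiens), read by scintillation counting, with a stated time of 120 min, tested at 10 uM (a higher number here means more inhibition at the concentration tested (going by the name of the read-out), a lower number less inhibition), and compound 1 `Nc1scc(CN2CCN(c3cccc(F)c3)CC2)c1C(=O)c1ccc(Cl)cc1` gives 4%; the step of a number 3 percentage points lower from compound 1 to compound 2 (within the scatter) lies within the scatter, so both stand together at the low end of the scale. Compound 3 `Nc1scc(CN2CCN(c3cc(F)cc(F)c3)CC2)c1C(=O)c1ccc(Cl)cc1` differs from compound 2 by 3,5-difluorophenyl in place of 3,4-difluorophenyl on an amine nitrogen in a ring. For the measured compounds named here, no measured step moves a fluorine from one position to another, and the only step that adds a fluorine changed little, so for compound 3 the expected step of a number 1 percentage points higher from compound 2 to compound 3 (within the scatter) is none beyond the scatter. Compound 3 is therefore estimated at 2% in this assay, within a range of -6% to 10%.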

Compound 3, a percentage reported as inhibition, at one concentration (the size of the read-out at that concentration, not a potency): 2%
The estimate for compound 3 equals the measured number at the digits printed; measured number inside the range.
By their numbers in this assay, from the lowest: compounds 2, 3 and 1 (each within the scatter of the next).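

In this assay the step of a number 1 percentage points higher from compound 2 to compound 3 (within the scatter) gives the first view of a fluorine changing place on this phenyl ring, and going from 3,4-difluorophenyl to 3,5-difluorophenyl moves nothing beyond the scatter. A second route to a difluorophenyl group, a number 2 percentage points lower from compound 1 to compound 3 (within the scatter) agrees with this, so neither the count of fluorines nor their arrangement separates these three compounds. Nothing available gives a reason for this.

On these data alone, whether a methoxy group or a chlorine on this phenyl ring would shift the number remains open.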